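Removing the trifluoromethyl from compound 3

This account rests on a few compounds, and the source may have more. Where it says the series, first, only, none or still open, it means among the compounds named here.

Compound 3 `CCC(C(=O)N1CCN(c2cccc(C(F)(F)F)c2)CC1)N1C(=O)CCC1=O` stands highest of the three numbers in a functional assay on the whole organism (strain Swiss) with Mus musculus as the target, in the maximal electroshock model, with a stated time of 0.5 h, at a dose of 300 mg/kg by the intraperitoneal route; on this read-out lower numbers stand for a weaker effect and higher numbers for a stronger effect at the one dose given: compound 3 gives 50%. Compound 1 `CCC(C(=O)N1CCN(c2ccc(F)cc2)CC1)N1C(=O)CCC1=O` gives 25% in this assay, and compound 2 `CCC(C(=O)N1CCN(c2ccccc2C(F)(F)F)CC1)N1C(=O)CCC1=O` gives 25%; both gaps to compound 3 lie beyond the scatter. Compound 4 `CCC(C(=O)N1CCN(c2ccccc2)CC1)N1C(=O)CCC1=O` has not yet been measured. It differs from compound 3 in one place: hydrogen in place of trifluoromethyl on an aromatic carbon. The group that leaves sits on an aromatic carbon of a six-membered aromatic ring of carbon only, meta to a large group. Among the measured compounds shown here, no step between measured compounds is at hand, so nothing shows directly how this change plays out. Two of the three measured compounds, compound 1 and compound 2, sit at the lower value, and compound 3 alone stands higher; compound 4, with nothing in place of the trifluoromethyl, is expected to fall back toward that lower level rather than hold the value of compound 3. The expected step in this assay is a drop beyond the scatter, a number 25 percentage points lower from compound 3 to compound 4 (beyond the scatter). Compound 4 is estimated at 25%, with a range from 0% to 55%.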

Compound 4, a percentage reported as activity, at one dose (the size of the read-out at that dose, not a potency): 75%
Compound 4: middle estimate off by 50 percentage points, on the low side; the measured number lies above the stated range.
By their numbers in this assay, from the lowest: compounds 1 and 2 (each within the scatter of the next); then compound 3; then compound 4.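

In this assay hydrogen in place of trifluoromethyl on an aromatic carbon, meta to a large group, gives a number 25 percentage points higher from compound 3 to compound 4 (beyond the scatter) and so shows that this group is not needed at this position for the effect at the one dose given. The other two steps point the same way, with a number 50 percentage points higher from compound 2 to compound 4 (beyond the scatter) on losing trifluoromethyl and a number 50 percentage points higher from compound 1 to compound 4 (beyond the scatter) on losing fluoro, so all three substituted compounds stand below compound 4, which carries hydrogen alone. Nothing at hand gives a reason for these steps.

From the compounds shown here alone, whether a methoxy group or an amine on this aromatic carbon would also stand below hydrogen stays open. Also open is whether the order of these compounds would hold at other doses or other times.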